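Swapping the ring on nitrogen in compound 2

The compounds below may be only part of what the source reports. "The series", "measured", "known", "first", "only" and "open" are said of these compounds alone.

Measured in a functional assay on HOS-TE85 cells (Homo sapiens) for inhibition, read by CCK-8 assay, with a stated time of 72 h; on this read-out higher numbers stand for weaker inhibition and lower numbers for stronger inhibition:
- compound 1 `O=C(NCCCCc1ccccc1)c1cccc(C2SCC(=O)N2c2cnccn2)c1`: > 1000 nM (a limit of the assay, not a number)
- compound 2 `O=C(NCCCCn1cccn1)c1cccc(C2SCC(=O)N2c2ccccn2)c1`: 60.3 nM
- compound 3 `O=C(NCCCCc1ccccc1)c1cccc(C2SCC(=O)N2c2ccccn2)c1`: 19.7 nM

Of the two exact numbers, compound 2 holds the higher, and the nearest step is a 3.1-fold lower number from compound 2 to compound 3 (0.49 log units; beyond the scatter). Compound 4 `O=C(NCCCCn1cccn1)c1cccc(C2SCC(=O)N2c2cccc(C3CC3)c2)c1` keeps the chain of compound 2 and changes the other end, with 3-cyclopropylphenyl in place of pyridin-2-yl on an amide-type nitrogen in a ring. Among the compounds with values here, the one measured change at this place is large, an at least 50-fold lower number from compound 1 to compound 3 (1.70 log units; beyond the scatter), so the place is sensitive. That change involves different groups, however, and gives no firm direction. Little net change, with wide uncertainty, is therefore expected in this assay, and the expected step is a 1.5-fold lower number from compound 2 to compound 4 (0.18 log units; within the scatter). Compound 4 is estimated at 40 nM, with an expected range of 6 nM to 300 nM.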

Compound 4, half-maximal inhibitory concentration: 299 nM
Beside the measured number, compound 4's estimate is 7.5-fold (0.87 log units) below it; measured number inside the range.
By their numbers in this assay, from the lowest: compound 3; then compound 2; then compound 4. At a limit, above all of these: compound 1.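

In this assay, within the data shown here, 3-cyclopropylphenyl in place of pyridin-2-yl gives a 5.0-fold higher number from compound 2 to compound 4 (0.70 log units; beyond the scatter), the first exact step at this position on the pyrazole chain. The larger, all-carbon group weakens inhibition here, yet the read-out remains a number for compound 4, so this change does not reach the assay limit: the limit of > 1000 nM in this assay, at which 1 of the 4 values shown sits.

Going by these compounds, whether the cyclopropyl or the loss of the ring nitrogen drives the step stays open; a plain phenyl at this position would separate the two. On these data alone, how 3-cyclopropylphenyl behaves with the phenyl-ended chain also remains open.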